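The compounds below may be only part of what the source reports. "The series", "measured", "known", "first", "only" and "open" are said of these compounds alone.

Compound 1 (`Fc1ccc(C2=NN(C3=NC(c4ccccc4)CS3)C(c3cccc4ccccc34)C2)cc1`) gives 12400 nM in a functional assay on HeLa cells (Homo sapiens) for inhibition, read by CCK-8 assay, with a stated time of 48 h; on this read-out lower numbers stand for stronger inhibition and higher numbers for weaker inhibition. Among the measured compounds shown here, it sits at the upper end of the three numbers measured so far, together with compound 2 (`Fc1ccc(C2=NN(C3=NC(c4ccccc4)CS3)C(c3ccc4ccccc4c3)C2)cc1`), which gives 9730 nM. Naphthalen-2-yl in place of naphthalen-1-yl on a saturated ring carbon amounts to a 1.3-fold lower number from compound 1 to compound 2 (0.11 log units; within the scatter), so that change cannot be told apart from repeat measurement. Compound 3 (`Cc1ccc(C2=NN(C3=NC(c4ccccc4)CS3)C(c3cccc4ccccc34)C2)cc1C`) gives 1720 nM, and 3,4-dimethylphenyl in place of 4-fluorophenyl amounts to a 7.2-fold lower number from compound 1 to compound 3 (0.86 log units; beyond the scatter).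

Compound 4 (`O=C1CSC(N2N=C(c3ccc(F)cc3)CC2c2cccc3ccccc23)=N1`) differs from compound 1 at another place, on an amine nitrogen in a ring: a group of 6 heavy atoms (3 carbon, 1 nitrogen, 1 oxygen, 1 sulfur; one five-membered non-aromatic ring with 2 hetero atoms) in place of a group of 11 heavy atoms (9 carbon, 1 nitrogen, 1 sulfur; one five-membered non-aromatic ring with 2 hetero atoms, one six-membered aromatic ring of carbon only), on an amine nitrogen in a ring. For the measured compounds named here, no measured compound varies this group, so neither step speaks to it directly. They show only how far changes elsewhere on the shared core have moved the number, from nothing measurable to a 7.2-fold lower number from compound 1 to compound 3 (0.86 log units; beyond the scatter). A change of this size, which removes a six-membered aromatic ring of carbon only, could plausibly shift the number by a similar modest amount, and a rise is expected more than a fall, though on thin evidence. The expected step is a 1.6-fold higher number from compound 1 to compound 4 (0.21 log units; within the scatter). The estimated value for compound 4 is 20000 nM, with an expected range from 6000 nM to 60000 nM.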

Compound 4, half-maximal inhibitory concentration: 11300 nM
For compound 4 the middle estimate is 1.8-fold (0.25 log units) above the measured one; measured number inside the range.
By their numbers in this assay, from the lowest: compound 3; then compounds 2, 4 and 1 (each within the scatter of the next).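

At this position, on an amine nitrogen in a ring, the group of 6 heavy atoms in place of the group of 11 heavy atoms gives in this assay a 1.1-fold lower number from compound 1 to compound 4 (0.04 log units; within the scatter), so this exchange cannot be told apart from repeat measurement. The earlier compounds shown here varied only the naphthyl attachment and the aryl group on the carbon with a double bond to nitrogen, whereas this pair shows that the six-membered aromatic ring of carbon only, present in the group that leaves and absent from the one that enters, can be lost here with no measurable shift in the number. No measurement on hand accounts for this outcome.

The compounds shown leave open whether the 3,4-dimethylphenyl group, which gave the one step beyond the scatter, would have a similar effect when paired with the group of 6 heavy atoms. They also leave open how the number would respond to an amine, a carboxylic acid or a longer chain on the five-membered non-aromatic ring with 2 hetero atoms.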